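A few compounds are considered here, and "the series" means these few. Any claim that something is new, unique, unknown or untested is made for them only; others in the source may bear on it.

Compound 1 `CC(C)NC1=NS(=O)(=O)c2cccnc2N1` carries an isopropyl group on the amine nitrogen of the shared core. In a functional assay (aorta) with Rattus norvegicus as the target (on this read-out lower numbers stand for an effect already at smaller amounts and higher numbers for an effect only at larger amounts of compound), compound 1 gives 132 uM. Compound 2 `CCC(C)NC1=NS(=O)(=O)c2cccnc2N1` differs from it only by methyl in place of hydrogen on a saturated chain carbon, two bonds along the chain from an amine nitrogen, and in this assay compound 2 gives 50.9 uM, which amounts to a 2.6-fold lower number from compound 1 to compound 2 (0.41 log units; beyond the scatter). Compound 3 `O=S1(=O)N=C(NCC2CCCCC2)Nc2ncccc21` has the same core but a different chain on the amine nitrogen; the difference between compound 1 and compound 3 is not broken down here. In this assay compound 3 gives 45.7 uM, a value that sits within the scatter of the value of compound 2.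

Compound 4 `C[C@H](NC1=NS(=O)(=O)c2cccnc2N1)C1CCCCC1` has not been measured. It differs from compound 3 by methyl in place of hydrogen on a saturated chain carbon bound to an amine nitrogen and a saturated ring carbon. Among the compounds with values here, this is the same kind of change as the one from compound 1 to compound 2, but the place is not the same: there the methyl entered two bonds along the chain from an amine nitrogen, here it enters on a saturated chain carbon bound to an amine nitrogen and a saturated ring carbon. Because the earlier step gave a 2.6-fold lower number from compound 1 to compound 2 (0.41 log units; beyond the scatter), compound 4 is expected to show a step of about a 1.6-fold lower number from compound 3 to compound 4 (0.21 log units; within the scatter). The estimate for compound 4 in this assay is 28 uM, with a plausible range from 12 uM to 70 uM.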

Compound 4, concentration for half-maximal effect: 29.2 uM
For compound 4 the middle estimate is 1.0-fold (0.02 log units) below the measured one; the measured number falls inside the stated range.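

In this assay, methyl in place of hydrogen on a saturated chain carbon bound to an amine nitrogen and a saturated ring carbon gives a 1.6-fold lower number from compound 3 to compound 4 (0.19 log units; within the scatter), so this step alone cannot be told apart from the ordinary spread of repeated measurements. Set beside the earlier step, it cannot be called different in size, so nothing here speaks against carrying this change from one core to the other: the same change on two cores in this assay, a 2.6-fold lower number (0.41 log units; beyond the scatter) from compound 1 to compound 2 and a 1.6-fold lower number (0.19 log units; within the scatter) from compound 3 to compound 4, 1.7-fold (0.22 log units) apart, within the scatter of two such steps

Within the data shown here, this does not show that the change carries over reliably, since it rests on only two pairs, the methyl enters at a different place in each, and only the earlier step stands clear of the scatter.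

Going by these compounds, it remains open whether an ethyl group or a hydroxyl group on that same chain carbon would give a step beyond the scatter. On these data alone, the mirror-image form of compound 4 also remains open, as does the effect of the same methyl on a chain ending in a phenyl ring.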